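The source may report more compounds than this note shows. Statements on the series, on what has been measured and on what is new or still open speak of the compounds shown alone.

The measurements here come from an assay on HEK293 cells for negative allosteric modulation of metabotropic glutamate receptor 5 (Homo sapiens), read by FLIPR, with a stated time of 1 h; a lower number here means a stronger inhibitor, a higher number a weaker inhibitor. Compound 1 `O=C1NCCc2nc(C#Cc3ccccc3F)sc21` carries a fluorine on its outer ring and a carbonyl in the shared core. In this assay compound 1 stops at > 10000 nM, a limit rather than a number. Compound 2 `CCN1CCc2nc(C#Cc3ccccc3)sc2C1` has an ethyl group on the ring nitrogen, and in this assay compound 2 gives 1200 nM. Compound 3 `O=C(C1CC12CCC2)N1CCc2nc(C#Cc3ccccc3)sc2C1` instead bears a spiro acyl group on that nitrogen. In this assay compound 3 also stops at > 10000 nM, which is a limit and not a number, so its position among the values shown is known only as sitting at that limit, where (the limit of > 10000 nM in this assay, at which 2 of the 3 values shown sit).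

For the measured compounds named here, the one step that has been measured runs an at least 8.3-fold higher number from compound 2 to compound 3 (0.92 log units; beyond the scatter). Going by the values given here, no measured step touches the acyl group itself.

Compound 4 `O=C(C1CCCCC1)N1CCc2nc(C#Cc3ccccc3)sc2C1` differs from compound 3 by a group of 6 heavy atoms (6 carbon; one six-membered non-aromatic ring of carbon only) in place of a group of 6 heavy atoms (6 carbon; one three-membered non-aromatic ring of carbon only, one four-membered non-aromatic ring of carbon only), on a carbonyl carbon. Since the only step available shows the acyl series already at the limit, and nothing shown separates one acyl group from another, the expected step that the limit leaves unreadable from compound 3 to compound 4 is close to none beyond the scatter, and compound 4 is expected to give about 15000 nM in this assay, within a range from 4000 nM to 60000 nM, most likely again reported as a limit.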

Compound 4, half-maximal inhibitory concentration: > 10000 nM
Compound 4: no number, only a limit; the forecaster's own chance of this, stated with the estimate: 70%; the middle value is on the limit's open side.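

Placing cyclohexyl on the carbonyl carbon in compound 4 leaves this assay with no number to compare against compound 3, so the step between these two compounds cannot be read, and neither can be ranked above the other: the limit of > 10000 nM in this assay, at which 3 of the 4 values shown sit.

What can be read is the change on the amine nitrogen in the ring, where cyclohexylcarbonyl in place of ethyl gives an at least 8.3-fold higher number from compound 2 to compound 4 (0.92 log units; beyond the scatter). Together with compound 3, this shows that the loss seen earlier is not peculiar to the spiro group, since two different carbon-only rings on the same carbonyl both end at a limit, while the ethyl compound gives a true number.

These results do not tell whether the carbonyl or the ring attached to it accounts for the change, nor how far compound 3 and compound 4 lie past the limit. A small acetyl group on that nitrogen, or a cyclohexyl or longer alkyl chain attached directly with no carbonyl, would be needed to separate those two parts.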